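Methyl for Bromo on Two Related Cores

The compounds below may be only part of what the source reports. "The series", "measured", "known", "first", "only" and "open" are said of these compounds alone.

Measured compounds:
Compound 1, `O=C1/C(=C/c2cccc(Br)c2)Cc2ccccc21`, gives 43300 nM in a functional assay on L1210 cells (Mus musculus) for inhibition; a higher number here means a weaker inhibitor, a lower number a stronger inhibitor.
Compound 2, `Cc1cccc(/C=C2\Cc3ccccc3C2=O)c1`, gives 50400 nM in this assay.
Compound 3, `O=C1/C(=C/c2cccc(Br)c2)CCCc2ccccc21`, gives 51000 nM in this assay.

The change from compound 1 to compound 2 is methyl in place of bromo on an aromatic carbon. It produced a 1.2-fold higher number from compound 1 to compound 2 (0.07 log units; within the scatter). Compound 3 and compound 1 differ in their cores; that difference is not broken down here, and their values lie within the scatter of each other.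

Compound 4, `Cc1cccc(/C=C2\CCCc3ccccc3C2=O)c1`, is not yet measured. It differs from compound 3 by methyl in place of bromo on an aromatic carbon. This is the same change as from compound 1 to compound 2, made on the core of compound 3. The step from compound 3 to compound 4 in this assay is therefore expected to be a 1.1-fold higher number from compound 3 to compound 4 (0.06 log units; within the scatter), resting on the observed 1.2-fold higher number from compound 1 to compound 2 (0.07 log units; within the scatter). Compound 4 is estimated at 58000 nM, between 30000 nM and 110000 nM.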

Compound 4, half-maximal inhibitory concentration: 54400 nM
The estimate for compound 4 lay 1.1-fold (0.03 log units) above the measured number; the range from low to high includes it.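

In this assay, methyl in place of bromo on an aromatic carbon gave a 1.1-fold higher number from compound 3 to compound 4 (0.03 log units; within the scatter), and set beside the earlier step, the change reads alike on the two cores: the same change on two cores in this assay, a 1.2-fold higher number (0.07 log units; within the scatter) from compound 1 to compound 2 and a 1.1-fold higher number (0.03 log units; within the scatter) from compound 3 to compound 4, 1.1-fold (0.04 log units) apart, within the scatter of two such steps. The result from the first core therefore carried over to the second, with no visible difference between the two steps. Among the compounds shown here, it does not show that the change has a real effect on either core, and with only two pairs, it says nothing about any other core.

The compounds shown leave open whether an amine or a carboxylic acid on that aromatic carbon would give a step beyond the scatter. They also leave open whether methyl and bromo would still match with a further group elsewhere on these cores.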